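Bromo for nitro on a second core: K562 antiproliferation

The compounds below may be only part of what the source reports. "The series", "measured", "known", "first", "only" and "open" are said of these compounds alone.

In a functional assay on K562 cells (Homo sapiens) for antiproliferative activity, read by MTT assay, with a stated time of 48 h (on this read-out higher numbers stand for weaker inhibition and lower numbers for stronger inhibition), three compounds have been measured:
compound 1, `CN(C)C(=O)N(Cc1ccco1)Cc1cc([N+](=O)[O-])ccc1O`, gives 28600 nM;
compound 2, `CCOC(=O)N1CCC(N(Cc2cc([N+](=O)[O-])ccc2O)C(=O)N(C)C)CC1`, gives 38400 nM;
compound 3, `CN(C)C(=O)N(Cc1ccco1)Cc1cc(Br)ccc1O`, gives 40500 nM.

Compound 3 differs from compound 1 in one place: bromo in place of nitro on an aromatic carbon. That change made a 1.4-fold higher number from compound 1 to compound 3 (0.15 log units; within the scatter). Compound 2 carries a different core; how the two cores differ is not broken down here, and the numbers for compound 2 and compound 1 lie within the scatter of each other, as do those for compound 2 and compound 3.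

Compound 4, `CCOC(=O)N1CCC(N(Cc2cc(Br)ccc2O)C(=O)N(C)C)CC1`, has not yet been measured. It differs from compound 2 by bromo in place of nitro on an aromatic carbon. Within the data shown here, this is the same change as the one from compound 1 to compound 3, made on the core of compound 2. In this assay the step expected is a 1.4-fold higher number from compound 2 to compound 4 (0.13 log units; within the scatter), which rests on the earlier step of a 1.4-fold higher number from compound 1 to compound 3 (0.15 log units; within the scatter); both lie within the scatter. On that basis compound 4 is estimated to give about 52000 nM, with the expected range running from 25000 nM to 110000 nM.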

Compound 4, half-maximal inhibitory concentration: 41800 nM
Compound 4: middle estimate off by 1.2-fold (0.09 log units), on the high side; low and high end bracket the measured number.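

In this assay, bromo in place of nitro on the core of compound 2 gives a 1.1-fold higher number from compound 2 to compound 4 (0.04 log units; within the scatter), and set beside the earlier step the comparison reads: the same change on two cores in this assay, a 1.4-fold higher number (0.15 log units; within the scatter) from compound 1 to compound 3 and a 1.1-fold higher number (0.04 log units; within the scatter) from compound 2 to compound 4, 1.3-fold (0.11 log units) apart, within the scatter of two such steps. Across these two cores, then, the change behaves alike in that neither step leaves the scatter and the two steps do not differ from each other. This does not show that the change is without effect or that it has a fixed size or direction, and two pairs in one assay say nothing about how it would behave on any other core.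

The compounds shown carry only nitro or bromo at the position para to a hydroxy group, so it stays open whether an amine, a carboxylic acid or a nitrile there would give a step beyond the scatter. On these data alone, it also stays open how the numbers would move if the hydroxy group were replaced by a methoxy group on either core.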